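Aryl Enone Boron Heterocycles: Cytotoxicity Toward a Non-Tumour Line

The source may hold more compounds than are shown below. What is called first, only, known or untested is meant among the compounds shown, and "the series" means these compounds.

Three enones sharing the cyclic boron core have been tested in a toxicity assay on MCF-10A cells (Homo sapiens) for cytotoxicity, read by MTT assay, with a stated time of 48 h; a higher number here means a weaker inhibitor, a lower number a stronger inhibitor. Compound 1 `Cn1cccc1C(=O)/C=C/c1ccc2c(c1)B(O)OC2` carries a 1-methyl-1H-pyrrol-2-yl group on the carbonyl carbon. In this assay compound 1 reaches only the limit of the measurement, > 100000 nM, so no number is known for it; it is one of the cases described by the limit of > 100000 nM in this assay, at which 1 of the 3 values shown sits. Compound 2 `CCc1ccc(C(=O)/C=C/c2ccc3c(c2)B(O)OC3)cc1` carries a 4-ethylphenyl group and in this assay compound 2 gives 8800 nM. Compound 3 `Cc1ccc(C(=O)/C=C/c2ccc3c(c2)B(O)OC3)cc1C` carries a 3,4-dimethylphenyl group and in this assay compound 3 gives 4700 nM; the two aryl ketones sit close together.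

Compound 4 `Nc1cccc(C(=O)/C=C/c2ccc3c(c2)B(O)OC3)c1` differs from compound 1 in one place: 3-aminophenyl in place of 1-methyl-1H-pyrrol-2-yl on a carbonyl carbon.

Going by the values given here, no measured pair isolates this change. The two aryl ketones, compound 2 and compound 3, both give numbers where compound 1 gives only a limit, so a step toward stronger inhibition from compound 1 to compound 4 is expected, though of uncertain size. The step from compound 1 to compound 4 is estimated as an at least 6.6-fold lower number from compound 1 to compound 4 (0.82 log units; beyond the scatter). Compound 4 is expected to give about 15000 nM in this assay, within 4000 nM to 100000 nM.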

Compound 4, half-maximal inhibitory concentration: 19600 nM
The estimate for compound 4 lay 1.3-fold (0.12 log units) below the measured number, and the stated range covers the measured number.
By their numbers in this assay, from the lowest: compounds 3 and 2 (each within the scatter of the next); then compound 4. At a limit, above all of these: compound 1.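

In this assay, 3-aminophenyl in place of 1-methyl-1H-pyrrol-2-yl on the carbonyl carbon gives an at least 5.1-fold lower number from compound 1 to compound 4 (0.70 log units; beyond the scatter), the first step read directly at this position. A measurable number at this place therefore does not require an alkyl-substituted phenyl group: a phenyl group carrying an amine, with a hydrogen-bond donor absent from 1-methyl-1H-pyrrol-2-yl, also gives one. The true size of the step stays unknown, because the value of compound 1 is a limit and not a number: the limit of > 100000 nM in this assay, at which 1 of the 4 values shown sits.

Still open, going by these compounds, is whether the six-membered ring or the amine carries the step, which an unsubstituted phenyl group on the carbonyl carbon would separate. Also open, on these data alone, is how a 4-aminophenyl group, or a carboxylic acid in place of the amine, would read in this assay.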